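The source may report more compounds than this note shows. Statements on the series, on what has been measured and on what is new or still open speak of the compounds shown alone.

Working notes on the series. Compound 1 `O=C(Nc1ccnnc1)c1cc(N2C[C@H]3COC[C@H]3C2)ccc1OCc1ccccc1` and compound 2 `CN1CC2(C1)CN(c1ccc(OCc3ccccc3)c(C(=O)Nc3ccnnc3)c1)C2` share a core and differ only in the amine substituent on the aromatic ring. In an assay on Sf9 cells for inhibition of Leucine-rich repeat serine/threonine-protein kinase 2 (Homo sapiens), read by TR-FRET, with stated times of 30 min and 2 h (a lower number here means a stronger inhibitor, a higher number a weaker inhibitor), compound 1 gives 50.1 nM. In the same assay compound 2 gives 25.1 nM. The step of a 2.0-fold lower number from compound 1 to compound 2 (0.30 log units; within the scatter) is the only one measured so far, and it lies within the scatter of repeated measurements, so compound 2 and compound 1 sit within the scatter of each other and no order between them can be claimed.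

Compound 3 `O=C(Nc1ccnnc1)c1cc(N2CCC(CO)CC2)ccc1OCc1ccccc1` has not been measured. It differs from compound 2 as follows: a group of 8 heavy atoms (6 carbon, 1 nitrogen, 1 oxygen; one six-membered non-aromatic ring with 1 hetero atom) in place of a group of 8 heavy atoms (6 carbon, 2 nitrogen; 2 four-membered non-aromatic rings with 1 hetero atom each), on an aromatic carbon. Within the data shown here, the one step measured exchanged one eight-atom ring substituent for another at the same aromatic carbon, and the number moved only within the scatter. The step from compound 2 to compound 3 is an exchange of the same kind at the same position, so no step beyond the scatter is expected in this assay, in either direction, and the expected step is a 1.3-fold higher number from compound 2 to compound 3 (0.11 log units; within the scatter). For compound 3 the estimated value in this assay is 32 nM, with a range from 10 nM to 100 nM.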

Compound 3, half-maximal inhibitory concentration: 20 nM
Estimate against measurement, compound 3: 1.6-fold (0.20 log units) above; measured number inside the range.
By their numbers in this assay, from the lowest: compounds 3, 2 and 1 (each within the scatter of the next, the first and the last beyond it).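

In this assay, the exchange of the two four-membered rings for 4-(hydroxymethyl)piperidin-1-yl gives a 1.3-fold lower number from compound 2 to compound 3 (0.10 log units; within the scatter), so no order between these two compounds can be claimed, even though the entering group carries a hydrogen-bond donor and the leaving group carries none. Among these compounds, the comparison with compound 1 is the first to pass the scatter: a 2.5-fold lower number from compound 1 to compound 3 (0.40 log units; beyond the scatter) is a modest step, and it shows that the group on this aromatic carbon, para to the benzyloxy group, can change the number measurably even when the heavy-atom count and composition of the group stay the same. No measurement at hand bears on the reason for either step.

The compounds shown leave open whether the hydroxyl of the hydroxymethyl group contributes at all, which a plain piperidin-1-yl or a carboxylic acid in place of the hydroxymethyl would help to settle. They also leave open how far the picture holds with a basic open-chain amine on this carbon, and whether it survives a change to the benzyloxy group, which is the same in all three compounds.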